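From Pyridin-2-yl to Pyrimidin-2-yl on the Carbonyl Carbon

This account rests on a few compounds, and the source may have more. Where it says the series, first, only, none or still open, it means among the compounds named here.

Of the compounds shown here, three with a shared core have been measured in a functional assay on COR-L23 cells (Homo sapiens) for antiproliferative activity, read by CellTiter-Glo, with a stated time of 4 days; a lower number here means a stronger inhibitor, a higher number a weaker inhibitor. There, compound 1 `CCC(=O)N[C@@H](C)c1ccc(NC(=O)[C@H]2C[C@@H]2c2cccnc2)cc1` gives 22 nM and compound 2 `C[C@H](NC(=O)CC(F)(F)F)c1ccc(NC(=O)[C@H]2C[C@@H]2c2cccnc2)cc1` gives 18 nM. Trifluoromethyl in place of methyl accounts for a 1.2-fold lower number from compound 1 to compound 2 (0.09 log units; within the scatter). Compound 3 `C[C@H](NC(=O)c1ccccn1)c1ccc(NC(=O)[C@H]2C[C@@H]2c2cccnc2)cc1` gives 46 nM, the highest number of the three and therefore the weakest inhibitor of the set.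

The next structure is compound 4 `C[C@H](NC(=O)c1ncccn1)c1ccc(NC(=O)[C@H]2C[C@@H]2c2cccnc2)cc1`, which has pyrimidin-2-yl in place of pyridin-2-yl on a carbonyl carbon.

The closest evidence comes from the two steps that introduced pyridin-2-yl at this carbonyl carbon. Replacing ethyl gave a 2.1-fold higher number from compound 1 to compound 3 (0.32 log units; beyond the scatter), and replacing 2,2,2-trifluoroethyl gave a 2.6-fold higher number from compound 2 to compound 3 (0.41 log units; beyond the scatter). Both steps were modest, but each replaced an open chain with an aromatic ring. Going by the values given here, no measured pair exchanges one aromatic ring for another, so the data offer no direct precedent and no firm direction. Since even those larger changes moved the number only modestly, a swap between two six-membered aromatic rings is expected to produce no step beyond the scatter in this assay. The estimated change is a 1.1-fold higher number from compound 3 to compound 4 (0.04 log units; within the scatter). For compound 4, the expected value is 50 nM, with an estimated range from 20 nM to 120 nM.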

Compound 4, half-maximal inhibitory concentration: 17 nM
For compound 4 the middle estimate is 2.9-fold (0.47 log units) above the measured one, and the stated range ends above it.
By their numbers in this assay, from the lowest: compounds 4, 2 and 1 (each within the scatter of the next); then compound 3.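

In this assay, going by these compounds alone, compound 4 gives the first exchange of one aromatic ring for another on this carbonyl carbon, and the step is beyond the scatter (a 2.7-fold lower number from compound 3 to compound 4 (0.43 log units; beyond the scatter)), so the number at this position depends on which six-membered aromatic ring is present and not only on whether a ring replaces an open chain. The higher number of compound 3 therefore does not extend to both aromatic rings shown, as pyrimidin-2-yl stays within the scatter of both open-chain amides, 2,2,2-trifluoroethyl (a 1.1-fold lower number from compound 2 to compound 4 (0.02 log units; within the scatter)) and ethyl (a 1.3-fold lower number from compound 1 to compound 4 (0.11 log units; within the scatter)), leaving compound 3 as the only one of the four set apart. Nothing at hand bears on what lies behind the difference between the two rings.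

The compounds shown leave open how a phenyl ring, with no ring nitrogen, or a pyrazin-2-yl ring would read on this carbonyl carbon, so they cannot say whether the count of ring nitrogens or their placement tracks the number. As far as these compounds go, all four compounds also keep the rest of the shared core unchanged, so it remains open whether the step from pyridin-2-yl to pyrimidin-2-yl would hold on a different core.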